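The compounds below may be only part of what the source reports. "The series", "measured", "known", "first", "only" and "open" are said of these compounds alone.

Measured in a physicochemical assay for solubility, read by HPLC, using the shake flask method, with a stated time of 2 h, at pH 2; on this read-out lower numbers stand for lower solubility and higher numbers for higher solubility:
- compound 1 `Nc1ncc(-c2ccc(C(=O)N3CCC(N)CC3)cc2)nc1-c1ccc(C(F)(F)F)cc1`: 200000 nM
- compound 2 `N#Cc1ccc(-c2cnc(N)c(-c3ccc(N)nc3)n2)cc1`: 208000 nM

Only these two compounds have been measured so far. Compound 1 gives 200000 nM and compound 2 gives 208000 nM, so the two values lie within the usual scatter of each other. Compound 1 therefore cannot be separated from compound 2 on these numbers.

The next compound is compound 3 `Nc1ncc(-c2ccc(C(=O)N3CC[C@H](O)C3)cc2)nc1-c1ccc(C(F)(F)F)cc1`, which keeps the core of compound 1 but changes the amide part. The change is 3-hydroxypyrrolidin-1-yl in place of 4-aminopiperidin-1-yl on a carbonyl carbon.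

For the measured compounds named here, no measured pair differs in just one place, so the data offer no direct guide to the size of this step, and what follows is a judgement with a wide margin. In this assay, a moderate fall beyond the scatter is expected, though no change remains possible. The estimate implies an expected 4.0-fold lower number from compound 1 to compound 3 (0.60 log units; beyond the scatter). For compound 3 the estimated value is 50000 nM, with an expected range from 8000 nM to 220000 nM.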

Compound 3, solubility: 93000 nM
Beside the measured number, compound 3's estimate is 1.9-fold (0.27 log units) below it; the range from low to high includes it.
By their numbers in this assay, from the lowest: compound 3; then compounds 1 and 2 (each within the scatter of the next).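

For the compounds shown here, this is the first sign that the amide part on the carbonyl carbon can move the number in this assay: 3-hydroxypyrrolidin-1-yl in place of 4-aminopiperidin-1-yl gives a modest step (a 2.2-fold lower number from compound 1 to compound 3 (0.33 log units; beyond the scatter)) while the rest of compound 1 stays the same. The change is a bundle, however: a five-membered ring replaces a six-membered ring, oxygen enters as nitrogen is reduced from two atoms to one in the group, and a defined stereocentre appears, while the counts of hydrogen-bond donors and acceptors stay equal. No separate measurement is available to explain the step.

Going by these compounds alone, the single step therefore cannot show whether ring size, the exchange of the amine for the hydroxyl group, or the stereocentre carries the difference. A 4-hydroxypiperidin-1-yl group would keep the six-membered ring while changing the amine to a hydroxyl group, whereas a 3-aminopyrrolidin-1-yl group would keep the amine on the five-membered ring, and each would isolate one part of this change.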